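This account rests on a few compounds, and the source may have more. Where it says the series, first, only, none or still open, it means among the compounds named here.

Measured so far in a physicochemical assay for lipophilicity, in phosphate buffer, measured as octanol-water partition, with a stated time of 24 h; a higher number here means a more lipophilic compound, a lower number a more polar compound:
compound 1, `S=C(N/N=C/c1ccc(Oc2ccc(Cl)cc2)cc1)Nc1ccccc1`, 5.52;
compound 2, `S=C(N/N=C/c1ccc(Oc2ccc3ccccc3c2)cc1)Nc1ccc(Br)cc1`, 6.93;
compound 3, `S=C(N/N=C/c1ccc(Oc2ccc(Br)cc2)cc1)Nc1ccc(Br)cc1`, 6.53.

Compound 3 stands second highest of the three numbers. Its nearest neighbour is compound 2, and the step of a number 0.40 log units lower from compound 2 to compound 3 (beyond the scatter), 4-bromophenyl in place of naphthalen-2-yl on the oxygen, lies beyond the scatter. Among the compounds with values here, compound 1 stands furthest from compound 3 and lower, beyond the scatter; the two differ in more than one place and no single step connects them.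

Compound 4, `S=C(N/N=C/c1ccc(Oc2ccc(Cl)cc2)cc1)Nc1ccc(Br)cc1`, has not yet been measured. The change from compound 3 to compound 4 is chloro in place of bromo on an aromatic carbon. Within the data shown here, no measured step in this set exchanges one halogen for another; the one step at hand, a number 0.40 log units lower from compound 2 to compound 3 (beyond the scatter), exchanges naphthalen-2-yl for 4-bromophenyl and does not bear on a bromo-to-chloro swap. Only a small step is therefore expected, in the lower direction if any. For compound 4 the expected step is a number 0.23 log units lower from compound 3 to compound 4 (within the scatter), at or near the edge of the scatter. The estimate for compound 4 is 6.3, with a range from 5.95 to 6.65.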

Compound 4, partition coefficient: 6.24
Compound 4: middle estimate off by 0.06 log units, on the high side; the measured number falls inside the stated range.
By their numbers in this assay, from the lowest: compound 1; then compounds 4 and 3 (each within the scatter of the next); then compound 2.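

In this assay, chloro in place of bromo on an aromatic carbon para to a large group gives the only halogen exchange among these compounds (a number 0.29 log units lower from compound 3 to compound 4 (within the scatter)), so bromo and chloro are not told apart at this position. The other halogen read here is bromo in place of hydrogen on an aromatic carbon (a number 0.72 log units higher from compound 1 to compound 4 (beyond the scatter)), a step beyond the scatter. 4-Chlorophenyl in place of naphthalen-2-yl on the oxygen (a number 0.69 log units lower from compound 2 to compound 4 (beyond the scatter)) is also beyond the scatter, as is the matching step with 4-bromophenyl, so naphthalen-2-yl stands apart from both halogenated rings.

No measurement at hand accounts for these steps. Open, going by these compounds, is how fluoro, an amine or a carboxylic acid at this aromatic carbon would read in this assay.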